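The source may hold more compounds than are shown below. What is called first, only, known or untested is meant among the compounds shown, and "the series" means these compounds.

Compound 1 `Cc1nn(C)c(C)c1-c1ccc(-c2nnc(N(C)Cc3ccc4nccn4c3)o2)c(Cl)c1` gives 2.51 nM in an assay on isolated protein for inhibition of tyrosine-protein kinase Mer (Homo sapiens), read by LC-MS; a higher number here means a weaker inhibitor, a lower number a stronger inhibitor. Compound 2 `Cc1cc(-c2c(C)nn(C)c2C)ccc1-c1nnc(N(C)Cc2ccc3nccn3c2)o1` gives 3.16 nM in this assay.

Compound 2 sits within the scatter of compound 1, the step being a 1.3-fold higher number from compound 1 to compound 2 (0.10 log units; within the scatter). Compound 3 `Cc1nn(C)c(C)c1-c1ccc(-c2nnc(N(C)Cc3ccc4nccn4c3)o2)c(C#N)c1` differs from compound 2 by cyano in place of methyl on an aromatic carbon. Within the data shown here, the only measured step at that position, chloro to methyl, stayed within the scatter, so a second exchange there is expected to move little. Compound 3 is therefore expected to show 3.5 nM in this assay, in the range 1.5 nM to 9 nM, a step of a 1.1-fold higher number from compound 2 to compound 3 (0.04 log units; within the scatter).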

Compound 3, half-maximal inhibitory concentration: 100000 nM
Compound 3: middle estimate off by 29000-fold (4.46 log units), on the low side, outside the stated range (above it).
By their numbers in this assay, from the lowest: compounds 1 and 2 (each within the scatter of the next); then compound 3.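

In this assay this position does not accept every exchange: chloro and methyl read alike, yet cyano in place of methyl brings a large loss (a 32000-fold higher number from compound 2 to compound 3 (4.50 log units; beyond the scatter)), and cyano in place of chloro does the same (a 40000-fold higher number from compound 1 to compound 3 (4.60 log units; beyond the scatter)). The flat reading from compound 1 and compound 2 therefore holds for those two groups only, not for the position as a whole. Nothing available explains this loss. On these data alone, whether it belongs to cyano alone or extends to other groups at this place, such as fluoro, methoxy or an amine, stays open.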